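The source may report more compounds than this note shows. Statements on the series, on what has been measured and on what is new or still open speak of the compounds shown alone.

Two quinoline amides have been measured for antiproliferative activity in a functional assay on MCF7 cells (Homo sapiens) for antiproliferative activity, read by MTT assay, with a stated time of 72 h; a higher number here means a weaker inhibitor, a lower number a stronger inhibitor. Compound 1, `Cc1cc(NCCN(C)C)nc2ccc(NC(=O)c3ccc(Cl)c(Cl)c3)cc12`, carries a dichlorinated benzamide and an open-chain amine, and in this assay compound 1 gives 2550 nM. Compound 2, `CCN1CCN(c2cc(C)c3cc(NC(=O)c4ccccc4Br)ccc3n2)CC1`, carries a brominated benzamide and a piperazine, and in this assay compound 2 gives 27500 nM. Of the two numbers, compound 2 stands at the higher, and compound 1 at the lower, a gap that lies beyond the usual scatter. Because the two compounds differ in more than one place, the gap cannot be laid at the door of either change alone.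

Compound 3, `CCN1CCN(c2cc(C)c3cc(NC(=O)c4ccco4)ccc3n2)CC1`, keeps the core and piperazine of compound 2 and alters only the amide: furan-2-yl in place of 2-bromophenyl on a carbonyl carbon. For the measured compounds named here, no measured pair in this set shows what such an exchange does. The step is therefore expected to be no larger than the scatter, a 1.1-fold higher number from compound 2 to compound 3 (0.04 log units; within the scatter), with the direction uncertain. In this assay compound 3 is estimated at 30000 nM, within a range from 8000 nM to 120000 nM.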

Compound 3, half-maximal inhibitory concentration: 41200 nM
For compound 3 the middle estimate is 1.4-fold (0.14 log units) below the measured one; the range from low to high includes it.
By their numbers in this assay, from the lowest: compound 1; then compounds 2 and 3 (each within the scatter of the next).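

For the compounds shown here, this is the first step in the set that reads a single change: with the core and piperazine of compound 2 held fixed, furan-2-yl in place of 2-bromophenyl on a carbonyl carbon gives a 1.5-fold higher number from compound 2 to compound 3 (0.18 log units; within the scatter) in this assay, so the two compounds cannot be told apart here. At this position, a six-membered aromatic ring of carbon only, carrying bromine, gives way to a five-membered aromatic ring with 1 hetero atom and a hydrogen-bond acceptor, and the read-out shows no difference beyond the scatter. Nothing at hand ties this step to any property of either group.

Compound 1 differs from compound 2 and from compound 3 in more than one place, so the compounds shown cannot say whether the gap between compound 1 and compound 2 belongs to the dichlorinated benzamide, the open-chain amine or both. They also leave open how an unsubstituted phenyl, a thiophene or a pyridine ring would read on the same carbonyl carbon, and what an open-chain amine in place of the piperazine would do with the amide of compound 2 kept.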